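The source may hold more compounds than are shown below. What is called first, only, known or untested is meant among the compounds shown, and "the series" means these compounds.

Of the compounds shown here, three built on one shared core have so far been tested in a functional assay on cells (Splenocyte, Mus musculus, strain BALB/c) for inhibition, read by scintillation counting and thymidine incorporation, with stated times of 48 h and 8 h; a higher number here means a weaker inhibitor, a lower number a stronger inhibitor. Compound 1 `COc1cc(-c2nc(Cc3c[nH]c4ccccc34)no2)cc(OC)c1OC` gives 11000 nM in this assay, and compound 2 `COc1ccccc1-c1nc(Cc2c[nH]c3ccccc23)no1` gives 16700 nM. Compound 3 `COc1ccc(-c2nc(Cc3c[nH]c4ccccc34)no2)cc1` returns only a limit of the assay, > 50000 nM. Compound 3 thus stands at the upper edge of the numbers shown, at the limit of > 50000 nM in this assay, at which 1 of the 3 values shown sits, and no figure for it is known beyond that. Compound 4 `COc1ccc(-c2nc(Cc3c[nH]c4ccccc34)no2)c(OC)c1` has not yet been measured in this assay. It differs from compound 3 in a single place: methoxy in place of hydrogen on an aromatic carbon. Within the data shown here, the group that enters is the one compound 2 carries, and compound 2 gives a measurable 16700 nM where compound 3 gives none, while compound 1 gives 11000 nM. On that basis a step toward stronger inhibition, beyond the usual scatter, is expected from an at least 2.5-fold lower number from compound 3 to compound 4 (0.39 log units; beyond the scatter), though the starting point is only a limit. Compound 4 is estimated at 20000 nM in this assay, with a range from 8000 nM to 50000 nM.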

Compound 4, half-maximal inhibitory concentration: 8600 nM
Compound 4: middle estimate off by 2.3-fold (0.37 log units), on the high side, within the range that was stated.
By their numbers in this assay, from the lowest: compounds 4, 1 and 2 (each within the scatter of the next). At a limit, above all of these: compound 3.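

In this assay, methoxy in place of hydrogen on an aromatic carbon, ortho to a large group and meta to a methoxy group, gives an at least 5.8-fold lower number from compound 3 to compound 4 (0.76 log units; beyond the scatter), so at this place the change separates the two compounds clearly. The same kind of exchange at another place on the ring gives a 1.9-fold lower number from compound 2 to compound 4 (0.29 log units; within the scatter), so there it makes no difference that can be told from the scatter. The size of the first step has only a lower bound, because the value of compound 3 is a limit and not a number: the limit of > 50000 nM in this assay, at which 1 of the 4 values shown sits.

On these data alone, how far that step truly reaches remains open. So does whether another group at this place, such as an amine, a hydroxyl or a longer chain like ethoxy, would act as methoxy does.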